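This account rests on a few compounds, and the source may have more. Where it says the series, first, only, none or still open, it means among the compounds named here.

Series notes. Compound 3 `CCCCCc1cc2ccccc2nc1-c1cn(-c2ccc(F)cc2)nn1` in a functional assay on HeLa cells (Homo sapiens) for cytotoxicity, read by MTT assay, with a stated time of 24 h (on this read-out lower numbers stand for stronger inhibition and higher numbers for weaker inhibition), gives > 100 ug/mL, which is a limit of the assay and not a number. Compound 1 `CCCCCCCCCCn1cc(-c2nc3ccccc3cc2CCCC)nn1` gives > 100 ug/mL, also a limit. Compound 2 `CCCCCCCCCCn1cc(-c2nc3ccccc3cc2CCC)nn1` gives > 100 ug/mL, again a limit. Every measured value is thus (the limit of > 100 ug/mL in this assay, at which 3 of the 3 values shown sit). Going by the values given here, the single step between measured compounds, a step that the two limits leave unreadable from compound 1 to compound 2, stays unreadable. Compound 4 `CCCCCCCCCCn1cc(-c2nc3ccccc3cc2CCCCC)nn1` differs from compound 3 by decyl in place of 4-fluorophenyl on an aromatic nitrogen. Among the compounds with values here, compounds 1 and 2 already carry the decyl group and show only limits, so no measured step bears on this change in a readable way, and no shift beyond the scatter is expected. The expected step is a step that the limit leaves unreadable from compound 3 to compound 4, consistent with a limit again. Compound 4 is estimated at 150 ug/mL in this assay, in the range 60 ug/mL to 400 ug/mL.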

Compound 4, half-maximal inhibitory concentration: > 100 ug/mL
Compound 4: no number, only a limit; the forecaster's own chance of this, stated with the estimate: 85%; the middle value is on the limit's open side.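

No step among compound 1, compound 2, compound 3 and compound 4 can be read, as each value is a limit of the assay: the limit of > 100 ug/mL in this assay, at which 4 of the 4 values shown sit.

The compounds shown leave open whether decyl, 4-fluorophenyl or the chain length on the shared core changes cytotoxicity at all.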